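Pentyl ether on a second core: expected growth inhibition

This account rests on a few compounds, and the source may have more. Where it says the series, first, only, none or still open, it means among the compounds named here.

Measured compounds:
compound 1 `COc1ccc2cc(CCCO)oc(=O)c2c1` gives 29 ug/mL
compound 2 `CCCCCOCCCc1cc2ccc(OC)cc2c(=O)o1` gives 5.5 ug/mL
compound 3 `COc1ccc2c(c1)C(=O)OC(CCCO)C2` gives 130 ug/mL

In an ADME assay on HaCaT cells (Homo sapiens) for cytotoxicity, read by sulforhodamine B assay, with a stated time of 48 h (on this read-out lower numbers stand for stronger inhibition of growth and higher numbers for weaker inhibition of growth), compound 1 gives 29 ug/mL and compound 2 gives 5.5 ug/mL. The two differ by one change, (pentyl in place of hydrogen on an oxygen on a saturated carbon), and that change gave a 5.3-fold lower number from compound 1 to compound 2 (0.72 log units; beyond the scatter). Compound 3 gives 130 ug/mL in this assay, the highest of the three numbers. The difference between the core of compound 1 and the core of compound 3 is not broken down here.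

Compound 4 `CCCCCOCCCC1Cc2ccc(OC)cc2C(=O)O1` is not yet measured. It differs from compound 3 by pentyl in place of hydrogen on an oxygen on a saturated carbon. Going by the values given here, this is the same change as the one from compound 1 to compound 2, at the same kind of place, on an oxygen on a saturated carbon whose other neighbours are a saturated chain carbon. The expectation for compound 4 rests on one earlier instance only, on a different core, so it is weakly founded. Still, in this assay the step is expected to be about a 5.2-fold lower number from compound 3 to compound 4 (0.72 log units; beyond the scatter), beside the earlier 5.3-fold lower number from compound 1 to compound 2 (0.72 log units; beyond the scatter). Compound 4 is thus expected to give about 25 ug/mL, with a range of 10 ug/mL to 65 ug/mL.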

Compound 4, concentration for 50% growth inhibition: 32.3 ug/mL
The estimate for compound 4 lay 1.3-fold (0.11 log units) below the measured number; low and high end bracket the measured number.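

In this assay the pentyl ether again gives a lower number on the second core, with a 4.0-fold lower number from compound 3 to compound 4 (0.60 log units; beyond the scatter), and the size of the step holds from one core to the other: the same change on two cores in this assay, a 5.3-fold lower number (0.72 log units; beyond the scatter) from compound 1 to compound 2 and a 4.0-fold lower number (0.60 log units; beyond the scatter) from compound 3 to compound 4, 1.3-fold (0.12 log units) apart, within the scatter of two such steps. For these two cores, then, the change carries over, and a step read on one core served as a fair guide to the other. This rests on two pairs and one ether group only, so it does not show that the step would hold on a further core, and it gives no reason why the number falls.

The compounds shown leave open how the step depends on the group itself: a methyl ether or a longer chain such as octyl on the same oxygen would show whether the size of the step follows chain length. Also open, on these data alone, is whether an amine or a carboxylic acid in place of the pentyl would keep the step on both cores.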